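A few compounds are considered here, and "the series" means these few. Any claim that something is new, unique, unknown or untested is made for them only; others in the source may bear on it.

Compounds measured in a functional assay on HeLa S3 cells (Homo sapiens) for antiproliferative activity, read by XTT assay, with a stated time of 72 h; a lower number here means a stronger inhibitor, a higher number a weaker inhibitor:
Compound 1, `COc1nc(N)nc2c1c(-c1cc3ccccc3o1)cn2[C@@H]1O[C@H](CO)[C@@H](O)[C@H]1O`: compound 1 reaches only the limit > 20000 nM in this assay.
Compound 2, `C#Cc1cn([C@@H]2O[C@H](CO)[C@@H](O)[C@H]2O)c2ncnc(OC)c12`: compound 2 gives 1730 nM in this assay.
Compound 3, `CN(C)c1ncnc2c1c(-c1cc3ccccc3o1)cn2[C@@H]1O[C@H](CO)[C@@H](O)[C@H]1O`: compound 3 reaches only the limit > 20000 nM in this assay.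

Compound 3 stands at the limit of this assay, and no number is known for it; compound 1 sits at the same limit, so two of the three values shown are limits (the limit of > 20000 nM in this assay, at which 2 of the 3 values shown sit). Only compound 2, which carries the ethynyl group, gives a number in this assay.

Compound 4, `C#Cc1cn([C@@H]2O[C@H](CO)[C@@H](O)[C@H]2O)c2ncnc(N(C)C)c12`, is the next compound. It differs from compound 3 in one place: ethynyl in place of 1-benzofuran-2-yl on an aromatic carbon. Among the compounds with values here, no step between measured compounds isolates this change, but compound 2 shows that a compound with the ethynyl group can give a measurable number, whereas both benzofuran compounds stay at the limit. The step of an at least 6.6-fold lower number from compound 3 to compound 4 (0.82 log units; beyond the scatter) is therefore expected to be in the direction of a stronger inhibitor, beyond the usual scatter. Compound 4 is estimated at 3000 nM in this assay, within a range of 800 nM to 15000 nM.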

Compound 4, half-maximal inhibitory concentration: 810 nM
For compound 4 the middle estimate is 3.7-fold (0.57 log units) above the measured one; the range from low to high includes it.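

Replacing 1-benzofuran-2-yl with ethynyl on this aromatic carbon gives an at least 24-fold lower number from compound 3 to compound 4 (1.39 log units; beyond the scatter) in this assay, so with dimethylamino held fixed, this one change separates a compound at the limit from one with a number. That step is only a bound, because compound 3 has a limit and not a number: the limit of > 20000 nM in this assay, at which 2 of the 4 values shown sit. Dimethylamino in place of methoxy on another aromatic carbon, with ethynyl kept, gives a 2.1-fold lower number from compound 2 to compound 4 (0.33 log units; beyond the scatter), a modest step beside the first.

On these data alone, whether the triple bond itself matters, or only the departure of 1-benzofuran-2-yl, stays open, and an ethyl or a phenyl group on this carbon would tell the two apart. As far as these compounds go, how much weaker compound 3 truly is than its limit also remains unknown.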